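The compounds below may be only part of what the source reports. "The series", "measured", "known", "first", "only" and "open" are said of these compounds alone.

Among the measured compounds shown here, compound 2 `CCc1ccc(Cl)c(C(=O)NC(=O)Nc2nc3ccc(S(=O)(=O)CCCN4CCN(C)CC4)cc3s2)c1` is the more lipophilic of the two measured compounds in a physicochemical assay for lipophilicity (a higher number here means a more lipophilic compound, a lower number a more polar compound), where compound 2 gives 2.9; its only neighbour, compound 1 `CN1CCN(CCCS(=O)(=O)c2ccc3nc(NC(=O)NC(=O)c4cccc(-n5cccn5)c4Cl)sc3c2)CC1`, gives 1.6 in this assay, the step being a number 1.30 log units higher from compound 1 to compound 2 (beyond the scatter). Compound 3 `Cc1ccn(-c2ccc(Cl)c(C(=O)NC(=O)Nc3nc4ccc(S(=O)(=O)CCCN5CCN(C)CC5)cc4s3)c2)n1` differs from compound 2 by 3-methyl-1H-pyrazol-1-yl in place of ethyl on an aromatic carbon. For the measured compounds named here, the one measured step bears directly on this exchange, since it swapped an ethyl against a pyrazolyl ring and was large, so a large drop is expected here, tempered by the added methyl. Compound 3 is therefore estimated at 2, between 1.5 and 2.5, an expected step of a number 0.90 log units lower from compound 2 to compound 3 (beyond the scatter).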

Compound 3, distribution coefficient: 2.6
For compound 3 the middle estimate is 0.60 log units below the measured one; the measured number lies above the stated range.
By their numbers in this assay, from the lowest: compound 1; then compounds 3 and 2 (each within the scatter of the next).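

On the aromatic carbon para to the chloro group, exchanging ethyl for 3-methyl-1H-pyrazol-1-yl gives a number 0.30 log units lower from compound 2 to compound 3 (within the scatter) in this assay, although the entering group brings an aromatic ring and hydrogen-bond acceptors. The large step of a number 1.30 log units higher from compound 1 to compound 2 (beyond the scatter) therefore does not carry over to this position, so a pyrazolyl ring alone does not set the size of the step across these compounds. Nothing available explains this difference between the two steps. On these data alone, it remains open whether 1H-pyrazol-1-yl without its methyl, an amine or a carboxylic acid on this carbon would also stay within the scatter of compound 2.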